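This account rests on a few compounds, and the source may have more. Where it says the series, first, only, none or still open, it means among the compounds named here.

Compound 1 `C/C(=C\CC/C(C)=C/CC[C@@H]1[C@@]2(C)CCC(=O)C(C)(C)[C@H]2CC[C@@]1(C)O)CC/C=C(\C)C(=O)OCc1cn(-c2ccccc2C)nn1` — in a functional assay on DU-145 cells (Homo sapiens) for antiproliferative activity, read by MTT assay, with a stated time of 48 h (a higher number here means a weaker inhibitor, a lower number a stronger inhibitor), compound 1 gives > 150000 nM, which is a limit of the assay and not a number.
Compound 2 `C/C(=C\CC/C(C)=C/CC[C@@H]1[C@@]2(C)CCC(=O)C(C)(C)[C@H]2CC[C@@]1(C)O)CC/C=C(\C)C(=O)OCc1cn(-c2cccc(Cl)c2)nn1` — in this assay compound 2 gives 103000 nM.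
Compound 3 `COc1cccc(-n2cc(COC(=O)/C(C)=C/CC/C(C)=C/CC/C(C)=C/CC[C@@H]3[C@@]4(C)CCC(=O)C(C)(C)[C@H]4CC[C@@]3(C)O)nn2)c1` — in this assay compound 3 gives > 150000 nM, which is a limit of the assay and not a number.

Compound 1 therefore stands only as a limit, not as a number, and it shares that position with one other compound, as the limit of > 150000 nM in this assay, at which 2 of the 3 values shown sit, shows. Compound 4 `C/C(=C\CC/C(C)=C/CC[C@@H]1[C@@]2(C)CCC(=O)C(C)(C)[C@H]2CC[C@@]1(C)O)CC/C=C(\C)C(=O)OCc1cn(-c2ccccc2Br)nn1` differs from compound 1 in one place: bromo in place of methyl on an aromatic carbon.

The measured steps that bear on this change all alter the aryl substituent on the aromatic nitrogen: an at least 1.4-fold lower number from compound 1 to compound 2 (0.16 log units; that floor lies within the scatter), a step that the two limits leave unreadable from compound 1 to compound 3 and an at least 1.4-fold higher number from compound 2 to compound 3 (0.16 log units; that floor lies within the scatter). None of them is a bromo for methyl exchange, and none is readable beyond the scatter. Nothing here points to a step in either direction beyond the scatter, so compound 4 is expected to stay close to where compound 1 sits. Compound 4 is estimated at 140000 nM, with a range from 70000 nM to 300000 nM. This estimate means an expected step of an at least 1.0-fold lower number from compound 1 to compound 4 (0.02 log units; that floor lies within the scatter).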

Compound 4, half-maximal inhibitory concentration: > 150000 nM
Compound 4 ended at the assay's limit; the forecaster's own chance of this, stated with the estimate: 60%; at least 1.0-fold (0.02 log units) between middle value and limit.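

With bromo in place of methyl on this aromatic carbon, ortho to a large group, compound 4 is still a limit of the assay and not a number, so this change shows no readable potency in this assay: the limit of > 150000 nM in this assay, at which 3 of the 4 values shown sit.

The steps from compound 4 to compound 1 and compound 3 cannot be read, as both ends of each are limits. For the compounds shown here, the one readable step is an at least 1.4-fold higher number from compound 2 to compound 4 (0.16 log units; that floor lies within the scatter), so the 2-bromophenyl and 3-chlorophenyl groups are not told apart beyond the scatter.

From the compounds shown here alone, whether an amine or a carboxylic acid in place of the bromo would bring a value clear of the limit remains open. Also open, going by these compounds, is how a bromo would read in the place that the chloro of compound 2 occupies.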